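One Inverted Stereocentre and Antiproliferative Activity

A few compounds are considered here, and "the series" means these few. Any claim that something is new, unique, unknown or untested is made for them only; others in the source may bear on it.

Among the measured compounds shown here, only two compounds have been measured in a functional assay on HepG2 cells (Homo sapiens) for antiproliferative activity (on this read-out lower numbers stand for stronger inhibition and higher numbers for weaker inhibition), so far. Compound 1 `Nc1nc(=O)n([C@H]2C=C[C@@H](CO)O2)cc1Br` gives > 100000 nM, which is a limit of the assay and not a number. For the measured compounds named here, compound 2 `O=c1[nH]c(=O)n([C@@H]2C=C[C@@H](CO)O2)cc1F` gives 37100 nM, the only true number available, so there is no series of measured values in which to rank it.

Compound 3 `O=c1[nH]c(=O)n([C@@H]2C=C[C@H](CO)O2)cc1F` keeps the same atoms and bonds as compound 2. The change is the two compounds have the same atoms and bonds and differ only in configuration as drawn: 1 of 2 stereo elements differ; a stereocentre at a saturated ring carbon is drawn S in compound 2 and R in compound 3: a stereocentre at a saturated ring carbon is drawn S in compound 2 and R in compound 3. Going by the values given here, no measured pair shows what such an inversion does in this assay, so a confident prediction is not possible. A small shift toward weaker inhibition is expected, possibly no larger than the scatter. The expected change is a 1.3-fold higher number from compound 2 to compound 3 (0.13 log units; within the scatter). Compound 3 is estimated to give 50000 nM, within an expected range from 15000 nM to 150000 nM.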

Compound 3, half-maximal inhibitory concentration: 35400 nM
Compound 3: the middle estimate sits 1.4-fold (0.15 log units) above what was measured; the measured number falls inside the stated range.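

Inverting the stereocentre at a saturated ring carbon gives a 1.0-fold lower number from compound 2 to compound 3 (0.02 log units; within the scatter) in this assay, so at this position the drawn configuration makes no difference that stands clear of the scatter. Among the compounds shown here, this is the first pair that can be read as a single change, and the comparison is a clean one: the fact that compounds 2 and 3 differ only in the configuration as drawn Compound 1 gives > 100000 nM, which is a limit of the assay and not a number, and it differs from the other compounds in more than one place, so it adds nothing to this reading.

From the compounds shown here alone, it remains open whether inverting the other stereo element would leave the number just as unmoved. Also open, going by these compounds, is what would happen if chlorine or a methyl group replaced the fluorine, or if a carboxylic acid or an amine replaced the hydroxymethyl group.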